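A few compounds are considered here, and "the series" means these few. Any claim that something is new, unique, unknown or untested is made for them only; others in the source may bear on it.

Of the compounds shown here, three of a shared core have been measured in a functional assay on cells (Lymphocyte, Homo sapiens), read by trypan blue exclusion, with a stated time of 16 h, tested at 0.1 uM; a lower number here means a weaker effect, a higher number a stronger effect of the compound at the concentration tested. Compound 1 `Cc1c(N(C)C)nc(CCCCCCCCCCO)c(O)c1C` gives 17%. Compound 2 `CCCCCCCCCCCCCCCCCCCc1c(C)c(N(C)C)nc(C)c1O` gives 20%. Compound 3 `CCCCCCCCCCc1nc(N(C)C)c(C)c(C)c1O` gives 36%. Among these three numbers compound 2 stands second highest: it lies within the scatter of compound 1, and beyond the scatter below compound 3, so nothing can be said about an order between compound 2 and compound 1.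

Among the compounds with values here, only one pair of measured compounds differs in a single place. The step of a number 19 percentage points higher from compound 1 to compound 3 (beyond the scatter) shows that losing the hydroxy group at the far end of the long chain raises the activity to a modest extent.

Compound 4 `CCCCCCCCCCCCCCCCc1c(C)c(N(C)C)nc(C)c1O` differs from compound 2 by hydrogen in place of propyl on a saturated chain carbon, ten or more bonds along the chain from an aromatic carbon. This is a shortening of the long chain, not a loss or gain of a hydroxy group, so the measured step does not bear on it directly. Compound 3 and compound 2 carry chains of different length and also differ in where the chain sits, so their values alone cannot separate the two effects. The expectation is therefore a step of a number 3 percentage points higher from compound 2 to compound 4 (within the scatter), that is, no change beyond the scatter. Compound 4 is estimated at 23%, with a range from 8% to 40%.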

Compound 4, a percentage reported as activity, at one concentration (the size of the read-out at that concentration, not a potency): 52%
For compound 4 the middle estimate is 29 percentage points below the measured one, and the stated range ends below it.
By their numbers in this assay, from the lowest: compounds 1 and 2 (each within the scatter of the next); then compound 3; then compound 4.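

In this assay, the outer part of the long chain matters even when no hydroxy group is involved: hydrogen in place of propyl, on a saturated chain carbon, gives a number 32 percentage points higher from compound 2 to compound 4 (beyond the scatter) and counts as a large change. The earlier step, a number 19 percentage points higher from compound 1 to compound 3 (beyond the scatter), was only modest and concerned a hydroxy group, whereas here only carbon atoms leave, so length alone can shift the read-out at this far end of the chain. No measurement at hand explains why this shortening is accompanied by a rise in the number.

With a single step in chain length, the compounds shown cannot tell whether the number keeps rising as the chain gets shorter or peaks at some length, since two lengths on this core give only two points on any such trend. Within the data shown here, also open is how this chain would behave if it ended in an amine or a carboxylic acid, as the only end group compared so far is a hydroxy group, on a chain of a different length and placement from that of compound 4.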